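Adding 4-methylpiperazin-1-yl to Compound 1

The compounds below may be only part of what the source reports. "The series", "measured", "known", "first", "only" and "open" are said of these compounds alone.

In a functional assay on K562 cells (Homo sapiens) for antiproliferative activity, read by MTT assay, with a stated time of 72 h (on this read-out lower numbers stand for stronger inhibition and higher numbers for weaker inhibition), compound 1 (`O=C(/C=C/c1cccc(/C=C/C(=O)c2ccccc2)n1)NO`) gives 510 nM and compound 2 (`CN1CCN(c2ccccc2C(=O)/C=C/c2cccc(/C=C/C(=O)NO)n2)CC1`) gives 700 nM as its value, so the two stand within the scatter of each other. Compound 3 (`CN1CCN(c2cccc(C(=O)/C=C/c3cccc(/C=C/C(=O)NO)n3)c2)CC1`) has not yet been measured. Its difference from compound 1 is 4-methylpiperazin-1-yl in place of hydrogen on an aromatic carbon and consists of 4-methylpiperazin-1-yl in place of hydrogen on an aromatic carbon, meta to a large group. Among the measured compounds shown here, one measured step bears on this, a like exchange of hydrogen for 4-methylpiperazin-1-yl on an aromatic carbon, and it came to a 1.4-fold higher number from compound 1 to compound 2 (0.14 log units; within the scatter) in all. In this assay no step beyond the scatter is therefore expected, in either direction. The expected change is a 1.2-fold higher number from compound 1 to compound 3 (0.07 log units; within the scatter) as an estimate. For compound 3 the estimated value is 600 nM with an expected range from 250 nM to 1400 nM on measurement.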

Compound 3, half-maximal inhibitory concentration in the K562 assay: 110 nM
Beside the measured number, compound 3's estimate is 5.5-fold (0.74 log units) above it; measured number below the stated range.
By their numbers in the K562 assay, from the lowest: compound 3; then compounds 1 and 2 (each within the scatter of the next).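

In the K562 assay, 4-methylpiperazin-1-yl on an aromatic carbon meta to a large group gives a step beyond the scatter, a 4.6-fold lower number from compound 1 to compound 3 (0.67 log units; beyond the scatter), whereas the exchange in compound 2 gave only a 1.4-fold higher number from compound 1 to compound 2 (0.14 log units; within the scatter). The earlier pair therefore did not show that this group can change the number at all; what counts here is where it sits on the ring, not only that it is present. The same exchange at this position also raises the number in a physicochemical assay for solubility, at pH 7.4; a lower number here means a less soluble compound, a higher number a more soluble compound: the measured solubility of compound 1, 16000 nM, and of compound 3, 380000 nM, a 24-fold higher number (1.38 log units; beyond the scatter)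
In the physicochemical assay compound 1 gives 16000 nM and compound 3 gives 380000 nM as measured.

The compounds shown do not tell whether the whole 4-methylpiperazin-1-yl group is needed for either step. A morpholin-4-yl group, a piperazin-1-yl group without the methyl, or a simple dimethylamino group at this position could separate the part played by the ring from that of its second nitrogen and methyl.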